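The source may report more compounds than this note shows. Statements on the series, on what has been measured and on what is new or still open speak of the compounds shown alone.

Measured so far in a functional assay on K562 cells (Homo sapiens) for cytotoxicity, read by MTT assay; a lower number here means a stronger inhibitor, a higher number a weaker inhibitor:
compound 1 `C=CCOc1cc(/C=C/C(=O)c2ccc(OC)c3c2OC(C)(C)C=C3)ccc1OC` gives the limit > 10000 nM, a limit of this assay and not a number.
compound 2 `CCCCC(=O)Oc1cc(/C=C/C(=O)c2ccc(OC)c3c2OC(C)(C)C=C3)ccc1OC` gives 240 nM.
compound 3 `COc1ccc(/C=C/C(=O)c2ccc(OC)c3c2OC(C)(C)C=C3)cc1OC(=O)C1CC1` gives 410 nM.

Compound 1 stands at the limit of > 10000 nM in this assay, at which 1 of the 3 values shown sits, so only a bound is known for it. Compound 4 `COc1ccc(/C=C/C(=O)c2ccc(OC)c3c2OC(C)(C)C=C3)cc1OC(=O)c1ccc(Br)cc1` differs from compound 1 by (4-bromophenyl)carbonyl in place of allyl on an oxygen on an aromatic ring. Within the data shown here, two measured steps bear on this: an at least 41-fold lower number from compound 1 to compound 2 (1.61 log units; beyond the scatter) and an at least 24-fold lower number from compound 1 to compound 3 (1.38 log units; beyond the scatter), both putting a carbonyl-bearing group on the same oxygen in place of allyl. The two acyl groups then sit close together, as a 1.7-fold higher number from compound 2 to compound 3 (0.23 log units; within the scatter). A large downward step is therefore expected for compound 4 in this assay, namely an at least 25-fold lower number from compound 1 to compound 4 (1.39 log units; beyond the scatter). The estimate for compound 4 is 400 nM, with a range from 130 nM to 1300 nM.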

Compound 4, half-maximal inhibitory concentration: 1110 nM
Beside the measured number, compound 4's estimate is 2.8-fold (0.44 log units) below it; the range from low to high includes it.
By their numbers in this assay, from the lowest: compounds 2 and 3 (each within the scatter of the next); then compound 4. At a limit, above all of these: compound 1.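

In this assay an aromatic acyl group on this oxygen still improves on allyl, with an at least 9.0-fold lower number from compound 1 to compound 4 (0.95 log units; beyond the scatter) as a bound only, since compound 1 stands at a limit of the assay: the limit of > 10000 nM in this assay, at which 1 of the 4 values shown sits.

The acyl groups are not interchangeable: 4-bromophenyl on the carbonyl carbon gives a 2.7-fold higher number from compound 3 to compound 4 (0.43 log units; beyond the scatter) and a 4.6-fold higher number from compound 2 to compound 4 (0.67 log units; beyond the scatter) and so separates from cyclopropyl and butyl, which stayed within the scatter of each other.

The compounds shown do not separate the effect of the phenyl ring from that of the bromine. From the compounds shown here alone, how a plain benzoyl or an acyl chain carrying an amine would stand on this oxygen remains open.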